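This account rests on a few compounds, and the source may have more. Where it says the series, first, only, none or still open, it means among the compounds named here.

Compound 1 `O=C(/C=C/c1ccc2c(c1)B(O)OC2)c1cccnc1` is compared with compound 2 `O=C(/C=C/c1ccc2c(c1)B(O)OC2)c1ccc(C(F)(F)F)cc1` and compound 3 `O=C(/C=C/c1ccc2c(c1)B(O)OC2)c1ccc(Cl)c(Cl)c1` in a functional assay on SK-OV-3 cells (Homo sapiens) for cytotoxicity, read by MTT assay, with a stated time of 48 h; a lower number here means a stronger inhibitor, a higher number a weaker inhibitor. Compound 1 gives 18500 nM and stands highest of the three; compound 2 gives 3700 nM and compound 3 gives 1800 nM, both lower by steps that lie beyond the usual scatter. The change to compound 4 `Cc1cccc(C(=O)/C=C/c2ccc3c(c2)B(O)OC3)c1` replaces the group on the carbonyl carbon (3-methylphenyl in place of pyridin-3-yl on a carbonyl carbon). Since both carbon-only aryl groups in compound 2 and compound 3 sit below compound 1 in this assay, a step downward beyond the scatter is expected for compound 4, from compound 1 to compound 4 estimated as a 3.7-fold lower number from compound 1 to compound 4 (0.57 log units; beyond the scatter). For compound 4 the expected value is 5000 nM, with a likely range from 2000 nM to 12000 nM.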

Compound 4, half-maximal inhibitory concentration: 2900 nM
Compound 4: middle estimate off by 1.7-fold (0.24 log units), on the high side; low and high end bracket the measured number.
By their numbers in this assay, from the lowest: compounds 3, 4 and 2 (each within the scatter of the next, the first and the last beyond it); then compound 1.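

In this assay, among the compounds shown here, the step to 3-methylphenyl on the carbonyl carbon gives a 6.4-fold lower number from compound 1 to compound 4 (0.80 log units; beyond the scatter), the first direct one-place comparison at this position. Compound 4 thus joins compounds 2 and 3, so all three carbon-only aryl groups shown lie below pyridin-3-yl, with none going against this. Nothing available explains the step. On these data alone, the change removes the ring nitrogen and adds a methyl group together, so their separate contributions remain open. Plain phenyl or a methyl-bearing pyridine ring would separate them, while an amine on the ring remains unexplored here.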